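This account rests on a few compounds, and the source may have more. Where it says the series, first, only, none or still open, it means among the compounds named here.

Working notes on the solubility series.

Compound 1 `CC(C)(O)CNC(=O)c1nc(CC2CCCCC2)c(-c2ccc(S(=O)(=O)NC3(C#N)CC3)c3ccccc23)s1` and compound 2 `CC(C)(O)CNC(=O)c1nc(CC2CCCCC2)c(-c2cnc(S(=O)(=O)NC(C)(C)C)c3ccccc23)s1` share the thiazole-amide scaffold but differ in more than one place, so their numbers are set side by side without a computed step. In a physicochemical assay for solubility, read by HPLC, in phosphate buffer, measured as thermodynamic solubility, with a stated time of 5 days, at pH 7, tested at 10 mM (on this read-out higher numbers stand for higher solubility and lower numbers for lower solubility), compound 1 gives 10000 nM. For compound 2 this assay reports only a limit, < 4000 nM, so compound 2 stands at the low end of the numbers shown and its true value is not known; the limit of < 4000 nM in this assay, at which 1 of the 2 values shown sits, marks where it sits.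

Compound 3 `CC(C)(C)NS(=O)(=O)c1ncc(-c2sc(C(=O)N[C@H]3C[C@H](C(=O)O)C3)nc2CC2CCCCC2)c2ccccc12` is not yet measured. It keeps the whole of compound 2 except at the amide-type nitrogen, where the change is 3-carboxycyclobutyl in place of 2-hydroxy-2-methylpropyl on an amide-type nitrogen. Going by the values given here, no step between measured compounds maps onto this change, so the expectation rests on the position of compound 2 alone: a step upward in this assay is expected, an at least 7.5-fold higher number from compound 2 to compound 3 (0.87 log units; beyond the scatter), larger than the usual scatter, though with wide uncertainty because compound 2 carries only a limit, < 4000 nM. For compound 3 the estimate in this assay is 30000 nM, within a range from 4000 nM to 150000 nM.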

Compound 3, solubility: 13000 nM
For compound 3 the middle estimate is 2.3-fold (0.36 log units) above the measured one; low and high end bracket the measured number.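

Going by these compounds alone, compound 3 gives the series its first one-place comparison, at the amide-type nitrogen, which the earlier compounds could not supply since compound 1 and compound 2 differ in more than one place. In this assay, 3-carboxycyclobutyl in place of 2-hydroxy-2-methylpropyl on an amide-type nitrogen gives an at least 3.2-fold higher number from compound 2 to compound 3 (0.51 log units; beyond the scatter), so this position does respond to a change of group and the step lies beyond the scatter. Only the lower end of the step's size is fixed, because compound 2 enters the comparison as a limit and not as a number: the limit of < 4000 nM in this assay, at which 1 of the 3 values shown sits.

The compounds shown leave open whether the step follows the carboxylic acid, the four-membered ring or the two together, a question that a plain cyclobutyl, an open-chain carboxylic acid or an amine on the same nitrogen would help to separate. Also open, on these data alone, are the part played by the two defined stereocentres, which the opposite arrangement on the ring would test, and whether the same change carries over to the cyano-cyclopropyl sulfonamide side of compound 1.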